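A few compounds are considered here, and "the series" means these few. Any claim that something is new, unique, unknown or untested is made for them only; others in the source may bear on it.

For the measured compounds named here, in a functional assay on SW-620 cells (Homo sapiens) for inhibition, read by sulforhodamine B assay, with a stated time of 48 h, tested at 100 uM (a lower number here means a stronger effect, a higher number a weaker effect of the compound at the concentration tested), the three measured members of the shared core spread widely. Compound 1 `COc1cc(Cl)cc(-c2nn(-c3cccc(NC(=O)Nc4ccc(Cl)c(C(F)(F)F)c4)c3)cc2-c2ccncc2)c1` gives -58%, compound 2 `COc1cc(Cl)cc(-c2nn(-c3cccc(NC(=O)Nc4cc(C(F)(F)F)cc(C(F)(F)F)c4)c3)cc2-c2ccncc2)c1` gives -72%, and compound 3 `COc1cc(Cl)cc(-c2nn(-c3cccc(NC(=O)Nc4ccc(Cl)c(Cl)c4)c3)cc2-c2ccncc2)c1` gives 7%, the highest of the three numbers, beyond the scatter from both others. Going by the values given here, the one single-change step recorded, a number 65 percentage points higher from compound 1 to compound 3 (beyond the scatter), is large. Compound 4 `COc1cc(Cl)cc(-c2nn(-c3cccc(NC(=O)Nc4cccc(C(F)(F)F)c4)c3)cc2-c2ccncc2)c1` differs from compound 3 by 3-(trifluoromethyl)phenyl in place of 3,4-dichlorophenyl on an amide-type nitrogen. This change runs against the direction of that step, bringing trifluoromethyl back in place of chloro, so a large step downward in this assay is expected, though the loss of the second substituent leaves its size uncertain. For compound 4 the estimate is -40% (range -75% to 0%), an expected step of a number 47 percentage points lower from compound 3 to compound 4 (beyond the scatter).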

Compound 4, a percentage reported as activity, at one concentration (the size of the read-out at that concentration, not a potency): -11%
Estimate against measurement, compound 4: 29 percentage points below; the measured number falls inside the stated range.
By their numbers in this assay, from the lowest: compound 2; then compound 1; then compound 4; then compound 3.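

In this assay, 3-(trifluoromethyl)phenyl in place of 3,4-dichlorophenyl on the amide-type nitrogen gives only a number 18 percentage points lower from compound 3 to compound 4 (beyond the scatter). Removing the second substituent weighs far more: hydrogen in place of trifluoromethyl gives a number 61 percentage points higher from compound 2 to compound 4 (beyond the scatter), and hydrogen in place of chloro gives a number 47 percentage points higher from compound 1 to compound 4 (beyond the scatter), so the single trifluoromethyl does not reach the low numbers of the two compounds carrying a second substituent. No measurement at hand accounts for these steps.

As far as these compounds go, what a methoxy, a nitrile or a carboxylic acid in place of trifluoromethyl on this ring would give stays open. So does the result for plain phenyl at this nitrogen.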